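The source may report more compounds than this note shows. Statements on the series, on what has been measured and on what is new or still open speak of the compounds shown alone.

Measured compounds:
Compound 1, `O=C(Nc1ccc(Cl)cn1)C1CCCN(C(=O)c2cc(C(F)(F)F)cc(C(F)(F)F)c2)C1`, gives 0%.
Compound 2, `C=Cc1cccc(C(=O)N2CCCC(C(=O)Nc3ccc(Cl)cc3)C2)c1`, gives 0%.
Compound 3, `C=CCOc1cccc(NC(=O)C2CCCN(C(=O)c3cc(C(F)(F)F)cc(C(F)(F)F)c3)C2)c1`, gives 0%.

In an ADME assay on PC-3 cells (Homo sapiens) for cytotoxicity, read by WST assay, tested at 100 uM (a lower number here means less inhibition, a higher number more inhibition at the concentration tested (going by the name of the read-out)), compound 2 stands level with compound 1 and compound 3. Among the compounds with values here, the single measured step, no change at the digits printed from compound 1 to compound 3 (within the scatter), exchanged the group on the amide-type nitrogen and left the read-out unmoved. Compound 4, `COC(=O)c1cccc(C(=O)N2CCCC(C(=O)Nc3ccc(Cl)cc3)C2)c1`, differs from compound 2 by methoxycarbonyl in place of vinyl on an aromatic carbon. Within the data shown here, no measured step touches that aromatic carbon or either of these groups, so the only guidance is that every change made so far, on this core, produced no inhibition at all. The step from compound 2 to compound 4 is therefore expected to stay within the scatter, no change at the digits printed from compound 2 to compound 4 (within the scatter). For compound 4 the estimate is 0%, with a range from 0% to 12%.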

Compound 4, a percentage reported as inhibition, at one concentration (the size of the read-out at that concentration, not a potency): 0%
For compound 4 middle estimate and measured number coincide at the digits printed; the measured number falls inside the stated range.
By their numbers in this assay, from the lowest: compounds 1, 2, 3 and 4 (each within the scatter of the next).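

In this assay the change at this aromatic carbon, meta to a large group, gives no change at the digits printed from compound 2 to compound 4 (within the scatter). Within the data shown here, the earlier step touched only the amide-type nitrogen, so this is the first reading at this position: methoxycarbonyl, which carries hydrogen-bond acceptors, stands level with vinyl, which carries none. No evidence here bears on why the read-out stays where it does.

The compounds shown leave open whether a carboxylic acid or an amine on this aromatic carbon would also stay level. They also leave open whether methoxycarbonyl would read the same on the core of compound 1.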